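Halogen exchange at the core of compound 1

The source may report more compounds than this note shows. Statements on the series, on what has been measured and on what is new or still open speak of the compounds shown alone.

Among the compounds with values here, compound 1, `Cc1cc(C(=O)O)nn1Cc1cc(Br)ccc1OCc1ccc(Cl)cc1Cl`, is the stronger of the two measured members of this small set. Within the data shown here, in an assay on CHO-K1 cells for displacement of a labelled ligand from prostaglandin E2 receptor EP1 subtype (Homo sapiens) (a lower number here means a stronger inhibitor, a higher number a weaker inhibitor), compound 1 gives 0.132 nM, the lowest of the two numbers known so far. Among the measured compounds shown here, compound 2, `Cc1cc(C(=O)O)nn1Cc1cc(Br)ccc1OCc1ccccc1Cl`, gives 3.16 nM in this assay, and the step of a 24-fold higher number from compound 1 to compound 2 (1.38 log units; beyond the scatter) is the only measured change available; it concerns the loss of a chloro from a different part of the structure, not the halogen at the position now in question.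

Compound 3, `Cc1cc(C(=O)O)nn1Cc1cc(Cl)ccc1OCc1ccc(Cl)cc1Cl`, has not yet been measured. It differs from compound 1 by chloro in place of bromo on an aromatic carbon. For the measured compounds named here, no measured step bears directly on a swap between two halogens at this carbon, and the one known step is of a different kind. The data therefore give no ground to expect a change beyond the scatter in this assay, at most a slightly higher number. The estimate for compound 3 in this assay is 0.2 nM, with a range from 0.07 nM to 0.6 nM. This estimate corresponds to an expected step of a 1.5-fold higher number from compound 1 to compound 3 (0.18 log units; within the scatter).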

Compound 3, half-maximal inhibitory concentration: < 2000 nM
Compound 3: only a limit was reported; the forecaster's own chance of this, stated with the estimate: 2%; the middle value lies beyond the limit too.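

In this assay compound 3 gives < 2000 nM, which is a limit of the assay and not a number. The step from compound 1 to compound 3 therefore cannot be read: the limit of < 2000 nM in this assay, at which 1 of the 3 values shown sits. The compounds shown leave open whether chloro in place of bromo on this aromatic carbon changes the number at all.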